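A Chloro Aryl Swap Carried Onto a Second Core

This account rests on a few compounds, and the source may have more. Where it says the series, first, only, none or still open, it means among the compounds named here.

Compound 1 `O=c1[nH]cc(S(=O)(=O)Nc2ccccc2-c2cn(-c3ccc(F)cc3)nn2)c(=O)[nH]1` and compound 2 `O=c1[nH]cc(S(=O)(=O)Nc2ccccc2-c2cn(-c3ccccc3Cl)nn2)c(=O)[nH]1` share one core; compound 3 `O=c1[nH]cc(S(=O)(=O)Nc2cccc(-c3cn(-c4ccc(F)cc4)nn3)c2)c(=O)[nH]1` and compound 4 `O=c1[nH]cc(S(=O)(=O)Nc2cccc(-c3cn(-c4ccccc4Cl)nn3)c2)c(=O)[nH]1` share another, and the difference between the two cores is not broken down here. All four are judged in a functional assay on OVCAR-3 cells (Homo sapiens) for antiproliferative activity, read by MTT assay, with a stated time of 24 h; on this read-out lower numbers stand for stronger inhibition and higher numbers for weaker inhibition. Compound 1 reaches only a limit of this assay, > 20000 nM. Compound 2 gives 3170 nM in this assay. Compound 3 likewise stops at a limit of this assay, > 20000 nM. Among the measured compounds shown here, the single change within the first pair, (2-chlorophenyl in place of 4-fluorophenyl on an aromatic nitrogen), brings an at least 6.3-fold lower number from compound 1 to compound 2 (0.79 log units; beyond the scatter); the size of that step is known only as a bound because of the limit of > 20000 nM in this assay, at which 2 of the 3 values shown sit. The change from compound 3 to compound 4 is the same one, (2-chlorophenyl in place of 4-fluorophenyl on an aromatic nitrogen), now made on the second core. Compound 4 has not yet been measured in this assay. The starting point is itself only the limit reached by compound 3. If the second core answers as the first did, the step expected is an at least 2.5-fold lower number from compound 3 to compound 4 (0.39 log units; beyond the scatter), though it begins from a bound rather than a number. Compound 4 is therefore estimated at 8000 nM, between 2500 nM and 25000 nM, and a further limit remains quite possible.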

Compound 4, half-maximal inhibitory concentration: 5370 nM
Estimate against measurement, compound 4: 1.5-fold (0.17 log units) above; measured number inside the range.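

In this assay, placing 2-chlorophenyl in place of 4-fluorophenyl on the aromatic nitrogen of the second core gives an at least 3.7-fold lower number from compound 3 to compound 4 (0.57 log units; beyond the scatter). The change lowers the number on both cores, so the direction carries over in these two pairs, but whether its size carries over remains unsettled: the same change on two cores in this assay, an at least 6.3-fold lower number (0.79 log units; beyond the scatter) from compound 1 to compound 2 and an at least 3.7-fold lower number (0.57 log units; beyond the scatter) from compound 3 to compound 4; the limit leaves it open whether they differ Neither step has a fixed size, and two cores cannot show how the change would behave on others, because each step starts from a limit of the assay: the limit of > 20000 nM in this assay, at which 2 of the 4 values shown sit.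

The compounds shown leave open whether the lower numbers follow the chlorine itself or its place on the phenyl ring, a question that a 4-chlorophenyl or a 2-fluorophenyl group on the same nitrogen would address. On these data alone, it also remains open how a group of another kind there, such as a benzyl group or a phenyl ring bearing an amine or a carboxylic acid, would read in this assay.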